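The source may report more compounds than this note shows. Statements on the series, on what has been measured and on what is new or still open speak of the compounds shown alone.

Working notes on the series. Compound 3 `CC(O)(C(=O)Nc1ccc(S(=O)(=O)c2ccc([N+](=O)[O-])cc2)cc1)C(F)(F)F` in a functional assay (Cavia porcellus) with sulfonylurea receptors; K-ATP channels (Homo sapiens) as the target (a higher number here means a weaker inhibitor, a lower number a stronger inhibitor), gives only a limit, > 30000 nM. Compound 1 `CC(O)(C(=O)Nc1ccc(S(=O)(=O)c2ccc(C#N)cc2)cc1)C(F)(F)F` likewise gives only a limit, > 30000 nM. Compound 2 `CC(O)(C(=O)Nc1ccc(S(=O)(=O)c2ccccc2Cl)cc1)C(F)(F)F` gives 2300 nM in this assay. Within the data shown here, the one readable step, an at least 13-fold lower number from compound 1 to compound 2 (1.11 log units; beyond the scatter), and its counterpart, an at least 13-fold higher number from compound 2 to compound 3 (1.11 log units; beyond the scatter), both end at the limit of > 30000 nM in this assay, at which 2 of the 3 values shown sit; the step that the two limits leave unreadable from compound 1 to compound 3 cannot be read.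

Compound 4 `CC(O)(C(=O)Nc1ccc(S(=O)(=O)c2ccccn2)cc1)C(F)(F)F` differs from compound 3 by pyridin-2-yl in place of 4-nitrophenyl on a sulfonyl sulfur. Among the measured compounds shown here, the measured steps show that the aryl on the sulfonyl sulfur moves the number strongly, but no step involves pyridin-2-yl, so the direction rests on compound 3 standing at a limit, from which only a lower number or another limit can follow. The step of an at least 2.5-fold lower number from compound 3 to compound 4 (0.39 log units; beyond the scatter) is an estimate only. Compound 4 is expected at 12000 nM, within 2500 nM to 30000 nM.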

Compound 4, half-maximal inhibitory concentration: 600 nM
For compound 4 the middle estimate is 20-fold (1.30 log units) above the measured one, outside the stated range (below it).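

Of the aryl groups shown on the sulfonyl sulfur, pyridin-2-yl gives the lowest number, with a 3.8-fold lower number from compound 2 to compound 4 (0.58 log units; beyond the scatter), so 2-chlorophenyl is no longer the best group at this position. The steps of an at least 50-fold lower number from compound 3 to compound 4 (1.69 log units; beyond the scatter) and an at least 50-fold lower number from compound 1 to compound 4 (1.69 log units; beyond the scatter) are larger, but they give only a minimum size because each starts at a limit: the limit of > 30000 nM in this assay, at which 2 of the 4 values shown sit.

The step between the two limit compounds remains unreadable. Open, going by these compounds, is whether the ring nitrogen or the loss of the substituent carries the change, which a plain phenyl, pyridin-3-yl or pyridin-4-yl on the sulfonyl sulfur would separate.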